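A few compounds are considered here, and "the series" means these few. Any claim that something is new, unique, unknown or untested is made for them only; others in the source may bear on it.

Compound 1 `CCCCCCCCOC(=O)C(O)Cn1cnc2c(N)ncnc21` gives 100 ug/mL in a functional assay on PRK cells (Oryctolagus cuniculus) for cytotoxicity; on this read-out lower numbers stand for higher toxicity in this test and higher numbers for lower toxicity in this test. Compound 2 `CCC(C)OC(=O)C(O)Cn1cnc2c(N)ncnc21` reaches only the limit of the method, > 400 ug/mL in this assay. Going by the values given here, the one measured step so far, an at least 4.0-fold higher number from compound 1 to compound 2 (0.60 log units; beyond the scatter), ends on that limit (the limit of > 400 ug/mL in this assay, at which 1 of the 2 values shown sits). Compound 3 `CC(C)OC(=O)C(O)Cn1cnc2c(N)ncnc21` differs from compound 2 by hydrogen in place of methyl on a saturated chain carbon, two bonds along the chain from an oxygen next to a carbonyl group. Among the compounds with values here, no measured step covers a change of this kind, and compound 2 already sits at the ceiling of the method, so no step beyond the scatter is expected in this assay. Compound 3 is therefore expected to give about 400 ug/mL, between 200 ug/mL and 800 ug/mL. The expected step is a number no higher from compound 2 to compound 3 (the limit leaves the size open), most likely reported once more as a limit.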

Compound 3, minimum cytotoxic concentration: > 400 ug/mL
Compound 3 was reported as a limit; the forecaster's own chance of this, stated with the estimate: 80%; the middle value sits exactly at the limit.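

In this assay compound 3 gives > 400 ug/mL, which is a limit and not a number. Isopropyl in place of octyl gives an at least 4.0-fold higher number from compound 1 to compound 3 (0.60 log units; beyond the scatter), so the shift seen with sec-butyl holds for a second short branched ester. The step between compound 2 and compound 3 cannot be read: the limit of > 400 ug/mL in this assay, at which 2 of the 3 values shown sit.

As far as these compounds go, how far beyond the limit either short ester lies stays open. Also open, from the compounds shown here alone, is where between these esters and octyl the read-out comes back within range, and whether a straight hexyl chain on the same oxygen or a free carboxylic acid would give a readable number.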